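A few compounds are considered here, and "the series" means these few. Any claim that something is new, unique, unknown or untested is made for them only; others in the source may bear on it.

Working notes on the series. Of the compounds shown here, two have been measured in a functional assay on cells (Cancer cell lines, Homo sapiens) for cytotoxicity, with a stated time of 48 h; a higher number here means a weaker inhibitor of growth, a lower number a stronger inhibitor of growth. Compound 1 `COc1c(/C=C2/C(=O)Nc3ccc(Cl)cc32)c2ccccc2n1-c1ccccc1` gives 24000 nM. Compound 2 `COc1cc2c(/C=C3/C(=O)Nc4ccc(O)cc43)c(Cl)n(Cc3cc(OC)c(OC)c(OC)c3)c2cc1C` gives 43700 nM; this and the number for compound 1 lie within the scatter of each other, so neither stands apart. Compound 3 `COc1cc2c(/C=C3/C(=O)Nc4cccc(Cl)c43)c(Cl)n(Cc3cc(OC)c(OC)c(OC)c3)c2cc1C` carries the change (a group of 12 heavy atoms (9 carbon, 1 nitrogen, 1 oxygen, 1 chlorine; one five-membered non-aromatic ring with 1 hetero atom, one six-membered aromatic ring of carbon only) in place of a group of 12 heavy atoms (9 carbon, 1 nitrogen, 2 oxygen; one five-membered non-aromatic ring with 1 hetero atom, one six-membered aromatic ring of carbon only), on an aromatic carbon). Within the data shown here, no measured pair separates the effect of this change, so no step beyond the scatter is expected in either direction. For compound 3 the expected step of a 1.5-fold lower number from compound 2 to compound 3 (0.16 log units; within the scatter) is therefore small, and compound 3 is estimated at 30000 nM, with a range from 9000 nM to 100000 nM.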

Compound 3, concentration for total growth inhibition: 22900 nM
Compound 3: middle estimate off by 1.3-fold (0.12 log units), on the high side; the measured number falls inside the stated range.
By their numbers in this assay, from the lowest: compounds 3, 1 and 2 (each within the scatter of the next).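

In this assay the first pair differing in one place gives a 1.9-fold lower number from compound 2 to compound 3 (0.28 log units; within the scatter) on an aromatic carbon of a five-membered aromatic ring with 1 nitrogen. At this place, the group with 1 chlorine and 1 hydrogen-bond donor is thus tolerated in place of the group with 2 oxygen and 2 hydrogen-bond donors, with no step beyond the scatter. No available measurement accounts for this result.

From the compounds shown here alone, whether an amine or a carboxylic acid on this group would give a step beyond the scatter remains open.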